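The source may report more compounds than this note shows. Statements on the series, on what has been measured and on what is new or still open speak of the compounds shown alone.

Measured so far in an ADME assay on liver (Mus musculus) for metabolic stability, read by LC-MS, using microsomes and NADPH; a higher number here means that more of the compound is left, a lower number that less of the compound is left:
compound 1, `CCCN(Cc1ccc(OCCN2C(=O)CCC2=O)c(C)c1)C(CC(=O)O)c1ccc(Cl)cc1`: 75%
compound 2, `CCCN(Cc1ccc(OCCN2C(=O)CCC2=O)c(C)c1)[C@H](CC(=O)O)c1ccc(Cl)cc1`: 69%
compound 3, `Cc1cc(CN(CC2CCCC2)C(CC(=O)O)c2ccc(Cl)cc2)ccc1OCCN1C(=O)CCC1=O`: 52%

Compound 1 holds the highest of the three numbers in this assay. Compound 2 is not separated from it: a number 6 percentage points lower from compound 1 to compound 2 (within the scatter), the two sharing all atoms and bonds, the only distinction being (the fact that one of compounds 1 and 2 is drawn with a defined configuration and the other without, at the place where they differ). Compound 3 does stand apart: a number 23 percentage points lower from compound 1 to compound 3 (beyond the scatter), a modest drop that follows cyclopentyl in place of ethyl on a saturated chain carbon bound to an amine nitrogen.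

Compound 4, `Cc1cc(CN(CCC(F)(F)F)C(CC(=O)O)c2ccc(Cl)cc2)ccc1OCCN1C(=O)CCC1=O`, is still to be measured in this assay. Against compound 1 the change is trifluoromethyl in place of methyl on a saturated chain carbon, two bonds along the chain from an amine nitrogen. Neither measured step touches this place. The step from compound 1 to compound 2 changes no atom at all; the step from compound 1 to compound 3 works on the carbon bound to the amine nitrogen, one bond closer in, and is the only move beyond the scatter, downward. Among the compounds with values here, no fluorine appears anywhere among the measured compounds, so there is no precedent for the direction of this step. The expectation is therefore a step near zero, a number 3 percentage points lower from compound 1 to compound 4 (within the scatter), with the range opened downward to admit a fall of the size seen for compound 3. Compound 4 is estimated at 72%, between 50% and 90%.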

Compound 4, percent of the compound remaining: 56%
Compound 4: the middle estimate sits 16 percentage points above what was measured; the range from low to high includes it.
By their numbers in this assay, from the lowest: compounds 3 and 4 (each within the scatter of the next); then compounds 2 and 1 (each within the scatter of the next).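

In this assay, within the data shown here, the chain on the amine nitrogen proves sensitive at a carbon further out than the one changed in compound 3: trifluoromethyl in place of methyl, two bonds along the chain from an amine nitrogen, gives a number 19 percentage points lower from compound 1 to compound 4 (beyond the scatter), the first fluorine-containing data point. The two departures from propyl now give results that are not separated, with 2,2,2-trifluoroethyl in place of cyclopentyl on a saturated chain carbon bound to an amine nitrogen giving a number 4 percentage points higher from compound 3 to compound 4 (within the scatter), even though the cyclopentylmethyl and 3,3,3-trifluoropropyl groups have little else in common by name. The available evidence, which concerns only how the configuration is drawn in compounds 1 and 2, does not bear on this result.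

Open, from the compounds shown here alone, is whether the step belongs to the fluorine atoms themselves or to the added heavy atoms at this place, a question that a butyl or 3-fluoropropyl chain on the amine nitrogen would address. Among these compounds, also open is whether the step carries over to the single configuration drawn in compound 2, and how a hydroxyl or a nitrile would behave at the same carbon.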